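Ester variation in a quinoline-type antiproliferative series

A few compounds are considered here, and "the series" means these few. Any claim that something is new, unique, unknown or untested is made for them only; others in the source may bear on it.

Three measured compounds share one core. Compound 1 `CSc1cnc2ccccc2c1SCC#CCOC(=O)/C=C/c1ccccc1`, in a functional assay on SW707 cells (Homo sapiens) for antiproliferative activity, with a stated time of 72 h (on this read-out lower numbers stand for stronger inhibition and higher numbers for weaker inhibition), gives 66.6 ug/mL, the highest of the three numbers. Compound 2 `CSc1cnc2ccccc2c1[Se]CC#CCOC(=O)/C=C/c1ccccc1` gives 4.7 ug/mL in this assay, and compound 3 `CSc1cnc2ccccc2c1[Se]CC#CCCl` gives 3.2 ug/mL; both stand far below compound 1, beyond the scatter. Going by the values given here, no single-site step between measured compounds is available, so the change to compound 4 `CSc1cnc2ccccc2c1SCC#CCOC(=O)c1ccc(C(=O)O)cc1` rests on compound 1 alone. The difference is 4-carboxyphenyl in place of 2-phenylethenyl on a carbonyl carbon. Nothing measured speaks to this swap, and no step beyond the scatter is expected. The value for compound 4 in this assay is estimated at 70 ug/mL, within 30 ug/mL to 160 ug/mL, which means an expected step of a 1.1-fold higher number from compound 1 to compound 4 (0.02 log units; within the scatter).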

Compound 4, concentration for 50% inhibition: 28.1 ug/mL
The estimate for compound 4 lay 2.5-fold (0.40 log units) above the measured number; the whole stated range lies above it.
By their numbers in this assay, from the lowest: compounds 3 and 2 (each within the scatter of the next); then compound 4; then compound 1.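

Going by these compounds alone, the only single-site step falls on the carbonyl carbon of the ester. In this assay, 4-carboxyphenyl in place of 2-phenylethenyl gives a 2.4-fold lower number from compound 1 to compound 4 (0.37 log units; beyond the scatter), so the number responds to the group at this position, though the change is modest. No available data account for this step.

From the compounds shown here alone, whether it follows from the carboxylic acid, the aromatic ring directly on the carbonyl carbon or the loss of the ethenyl link remains open. A plain phenyl group or a methyl ester of the acid at this position would help separate these.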